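This account rests on a few compounds, and the source may have more. Where it says the series, first, only, none or still open, it means among the compounds named here.

Going by the values given here, compound 1 `C[C@@H]1CN(c2sc(C(F)(F)F)nc2-c2nc3ccccc3[nH]2)CCN1C(=O)CN1C(=O)OC[C@@H]1c1ccccc1` is the weaker of the two compounds measured so far in a functional assay on CHO-K1 cells for antagonist activity at C-X-C chemokine receptor type 3 (Homo sapiens), read by FLIPR, with a stated time of 10 min, in the presence of a further agent that is not named here; a higher number here means a weaker inhibitor, a lower number a stronger inhibitor: in this assay compound 1 gives 360 nM, while compound 2 `C[C@@H]1CN(c2sc(C(F)(F)F)nc2-c2nc3cc(Cl)ccc3[nH]2)CCN1C(=O)Cn1cnc2cccnc21` gives 2.8 nM, and the gap between these two numbers lies well beyond the usual scatter of the measurement. Compound 2 differs from compound 1 in more than one place, so no single change can be tied to that gap.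

Compound 3 `C[C@@H]1CN(c2sc(C(F)(F)F)nc2-c2nc3ccccc3[nH]2)CCN1C(=O)Cn1cnc2c1CCN(C)C2` keeps the core of compound 1 and alters only the group on the saturated chain carbon bound to the carbonyl carbon: a group of 10 heavy atoms (7 carbon, 3 nitrogen; one five-membered aromatic ring with 2 hetero atoms, one six-membered non-aromatic ring with 1 hetero atom) in place of a group of 12 heavy atoms (9 carbon, 1 nitrogen, 2 oxygen; one five-membered non-aromatic ring with 2 hetero atoms, one six-membered aromatic ring of carbon only), on a saturated chain carbon bound to a carbonyl carbon. Among the compounds with values here, no measured pair shows exactly this change. Because compound 2, which carries a fused aromatic ring system at this same place, reaches 2.8 nM, the step from compound 1 to compound 3 is expected to lower the number in this assay by a clear margin, a 10-fold lower number from compound 1 to compound 3 (1.01 log units; beyond the scatter). Compound 3 is therefore estimated at 35 nM, within a range of 8 nM to 150 nM.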

Compound 3, half-maximal inhibitory concentration: 3.6 nM
Estimate against measurement, compound 3: 9.7-fold (0.99 log units) above; the whole stated range lies above it.
By their numbers in this assay, from the lowest: compounds 2 and 3 (each within the scatter of the next); then compound 1.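

In this assay, exchanging the 2-oxo-4-phenyl-1,3-oxazolidin-3-yl group for the new group gives a 100-fold lower number from compound 1 to compound 3 (2.00 log units; beyond the scatter), a large step. The gap between compound 1 and compound 2 could not be tied to any one place, but this pair shares the core of compound 1 and differs only on the saturated chain carbon bound to a carbonyl carbon, so a large change can now be placed there. It also shows that a six-membered aromatic ring of carbon only is not required in this group for a low number, since the entering group has none.

Nothing measured here explains why this exchange has so large an effect. As far as these compounds go, it remains open how a simpler group at this place, such as a plain amine or a carboxylic acid, would compare.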